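The source may report more compounds than this note shows. Statements on the series, on what has been measured and on what is new or still open speak of the compounds shown alone.

Measured compounds:
Compound 1, `CCCCNc1nc(-c2ccccc2)nc2c1nnn2Cc1ccccc1C(F)(F)F`, gives 6.5 nM.
Compound 2, `Clc1ccccc1Cn1nnc2c(NC3CCCCC3)nc(-c3ccccc3)nc21`, gives 34 nM.

Both were tested in an assay on Cerebral cortex for displacement of a labelled ligand from adenosine receptor A1 (Bos taurus); a lower number here means a stronger inhibitor, a higher number a weaker inhibitor. Of the two numbers, compound 2 stands at the higher one, and compound 1 stands below it by a gap that is beyond the usual scatter. Compound 1 and compound 2 differ in two places at once, so their two values show only that both bind, with compound 1 the stronger of the pair.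

Compound 3, `FC(F)(F)c1ccccc1Cn1nnc2c(NC3CCCCC3)nc(-c3ccccc3)nc21`, is not yet measured. It keeps the cyclohexylamino of compound 2 and takes the change (trifluoromethyl in place of chloro on an aromatic carbon). Among the compounds with values here, the step from compound 2 to compound 3 has no measured counterpart here. Compound 1 carries the same trifluoromethyl on the benzyl and gives 6.5 nM, so a modest downward step is expected, a 2.3-fold lower number from compound 2 to compound 3 (0.36 log units; beyond the scatter), though one within or near the scatter would not surprise. Compound 3 is estimated at 15 nM, with a range from 5 nM to 50 nM.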

Compound 3, inhibition constant: 6.8 nM
Compound 3: middle estimate off by 2.2-fold (0.34 log units), on the high side; low and high end bracket the measured number.
By their numbers in this assay, from the lowest: compounds 1 and 3 (each within the scatter of the next); then compound 2.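

In this assay the benzyl substituent can now be read on its own: with the cyclohexylamino held fixed, trifluoromethyl in place of chloro on the aromatic carbon gives a 5.0-fold lower number from compound 2 to compound 3 (0.70 log units; beyond the scatter) and so separates the two groups beyond the scatter. The group on the nitrogen can also be read on its own: with the 2-(trifluoromethyl)benzyl held fixed, cyclohexyl in place of butyl gives a 1.0-fold higher number from compound 1 to compound 3 (0.02 log units; within the scatter) and so lies within the scatter, leaving these two groups undistinguished here. Nothing at hand gives a cause for either step.

As far as these compounds go, the chloro to trifluoromethyl step is read only with cyclohexyl on the nitrogen, so whether it holds with butyl stays open. Also open, from the compounds shown here alone, is how a methoxy or a nitrile would compare on this aromatic carbon, and how a chain longer than butyl would compare on the nitrogen.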